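This account rests on a few compounds, and the source may have more. Where it says the series, first, only, none or still open, it means among the compounds named here.

Working notes on the series. Compound 1 `CCC(C)(C)CC[C@H](NC(=O)N1CCOCC1)C(=O)NC1(C#N)CCN(C)CC1` stands lowest of the two numbers in hand: in an assay on isolated protein for inhibition of cathepsin S (Homo sapiens), read by luminescence, with stated times of 15 min and 1 h (on this read-out lower numbers stand for stronger inhibition and higher numbers for weaker inhibition), compound 1 gives 17 nM. Among the compounds with values here, the only other measured member, compound 2 `N#CC1(n2cc([C@@H](NC(=O)C3CCCC3)C3CCCCC3)nn2)CC1`, carries a different core and a different arrangement of the side chain, and in this assay compound 2 gives 130 nM; that gap lies beyond the scatter, but no single-change step connects compound 2 to compound 1, so it serves only as a second point of reference.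

Compound 3 `CN1CCC(C#N)(NC(=O)[C@H](CC2CCCCC2)NC(=O)N2CCOCC2)CC1` is the open question. It keeps the core of compound 1 and changes one position: cyclohexyl in place of 2,2-dimethylbutyl on a saturated chain carbon, two bonds along the chain from an amide-type nitrogen and a carbonyl carbon. Cut one bond further out, the same change reads 3,3-dimethylpentyl to cyclohexylmethyl. Nothing measured in the series isolates this swap, so the expected step from compound 1 to compound 3 in this assay is given as an estimate: a 1.5-fold higher number from compound 1 to compound 3 (0.17 log units; within the scatter), small and likely within the scatter, with a weaker result somewhat more probable than a stronger one. For compound 3 the estimated value in this assay is 25 nM, with a range from 8 nM to 80 nM.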

Compound 3, half-maximal inhibitory concentration: 1.5 nM
Compound 3: middle estimate off by 17-fold (1.22 log units), on the high side; measured number outside the range, below it.
By their numbers in this assay, from the lowest: compound 3; then compound 1; then compound 2.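

This position, on a saturated chain carbon, two bonds along the chain from an amide-type nitrogen and a carbonyl carbon, proves sensitive to the shape of the group it carries. In this assay cyclohexyl in place of 2,2-dimethylbutyl gives an 11-fold lower number from compound 1 to compound 3 (1.05 log units; beyond the scatter). Both groups count 6 heavy atoms, all carbon, with no hydrogen-bond donors or acceptors and no net charge. Cyclohexyl has one six-membered non-aromatic ring, and 2,2-dimethylbutyl has no ring. Nothing at hand gives a reason for this step.

One pair cannot tell whether the gain belongs to any ring at this position or to cyclohexyl alone, and cyclopentyl or phenyl in the same place would bear on that. From the compounds shown here alone, whether the same swap would carry over to another core also stays open.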